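This account rests on a few compounds, and the source may have more. Where it says the series, first, only, none or still open, it means among the compounds named here.

Compound 1 `C=CCc1ccc(OCc2cn(-c3ccccc3Cl)nn2)c(O)c1`: 4.7%
Compound 2 `C=CCc1cc(O)c(O)c(CN2CCC(CCO)CC2)c1`: 2%
Compound 3 `C=CCc1ccc(OCc2cn(-c3ccc(C(=O)c4ccccc4)cc3)nn2)c(O)c1`: 16.2%

Three compounds have been run in a functional assay on HepG2 cells (Homo sapiens) for inhibition, read by MTT assay, with a stated time of 72 h, tested at 50 uM; a higher number here means more inhibition of growth at the concentration tested, a lower number less inhibition of growth. Compound 3 gives the highest of the three numbers; compound 1 lies lower by a margin beyond the usual scatter, and compound 2 lies lower still, also beyond the scatter. Among the compounds with values here, no two measured compounds differ in a single place, so no step has been followed within the measured set.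

Compound 4 `C=CCc1ccc(OCc2cn(-c3ccc(OC)cc3)nn2)c(O)c1` is not yet measured. It differs from compound 3 in one place: methoxy in place of benzoyl on an aromatic carbon. The rest of the structure is unchanged.

Within the data shown here, the only comparison at hand is compound 1, which gives 4.7%. Because compound 1 gives 4.7% and compound 3 gives 16.2%, the step of a number 8.2 percentage points lower from compound 3 to compound 4 (within the scatter) is expected to be a decrease of moderate size, possibly beyond the scatter. For compound 4 the value expected in this assay is 8%, with a range from 0% to 18%.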

Compound 4, percent growth inhibition at one concentration: 49.9%
Compound 4: the middle estimate sits 41.9 percentage points below what was measured; the measured number lies above the stated range.
By their numbers in this assay, from the lowest: compounds 2 and 1 (each within the scatter of the next); then compound 3; then compound 4.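

In this assay methoxy in place of benzoyl on an aromatic carbon, para to a large group, gives a large step (a number 33.7 percentage points higher from compound 3 to compound 4 (beyond the scatter)), so this position is sensitive to the group it carries. 4-methoxyphenyl in place of 2-chlorophenyl on an aromatic nitrogen gives a large step in the same direction (a number 45.2 percentage points higher from compound 1 to compound 4 (beyond the scatter)). Nothing available explains either step.

Only benzoyl and methoxy are compared at this position, so a trend with group size cannot be drawn. On these data alone, how an amine, a carboxylic acid or a longer alkoxy chain on that carbon would behave remains open.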